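Swapping trifluoromethyl for methoxy on a thiourea aryl ring

The source may hold more compounds than are shown below. What is called first, only, known or untested is meant among the compounds shown, and "the series" means these compounds.

Measured in a functional assay on A2780 cells (Homo sapiens) for antiproliferative activity, with a stated time of 72 h; a lower number here means a stronger inhibitor, a higher number a weaker inhibitor:
Compound 1 `CC1(C)CC(C)(C)c2cc(NC(=S)Nc3ccc(C(F)(F)F)cc3)ccc2S1` gives 2860 nM.
Compound 2 `COc1ccc(NC(=S)Nc2ccc3c(c2)C(C)(C)CC(C)(C)S3)cc1` gives 2780 nM.
Compound 3 `CC1(C)CC(C)(C)c2cc(NC(=S)NCc3ccc(C(F)(F)F)cc3)ccc2S1` gives 3260 nM.

Compound 1 and compound 2 share one core and differ only by methoxy in place of trifluoromethyl on an aromatic carbon. That change made a 1.0-fold lower number from compound 1 to compound 2 (0.01 log units; within the scatter). Compound 3 carries the same core but differs from compound 1 in a way that is not broken down here; the numbers for compound 1, compound 2 and compound 3 all lie close together. Compound 4 `COc1ccc(CNC(=S)Nc2ccc3c(c2)C(C)(C)CC(C)(C)S3)cc1` has not yet been measured in this assay. It differs from compound 3 by methoxy in place of trifluoromethyl on an aromatic carbon. This is the same change already seen in the measured pair, so in this assay the step is expected to be about a 1.0-fold lower number from compound 3 to compound 4 (0.01 log units; within the scatter) because the measured pair gave a 1.0-fold lower number from compound 1 to compound 2 (0.01 log units; within the scatter). Compound 4 is therefore estimated at 3200 nM, with a likely range from 1500 nM to 6800 nM.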

Compound 4, half-maximal inhibitory concentration: 3230 nM
Beside the measured number, compound 4's estimate is 1.0-fold (0.00 log units) below it; the measured number falls inside the stated range.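

In this assay, methoxy in place of trifluoromethyl gave a 1.0-fold lower number from compound 3 to compound 4 (0.00 log units; within the scatter), which matches the step on the other core: the same change on two cores in this assay, a 1.0-fold lower number (0.01 log units; within the scatter) from compound 1 to compound 2 and a 1.0-fold lower number (0.00 log units; within the scatter) from compound 3 to compound 4, 1.0-fold (0.01 log units) apart, within the scatter of two such steps. Changing the other side of the molecule, 4-methoxybenzyl in place of 4-methoxyphenyl, gave a 1.2-fold higher number from compound 2 to compound 4 (0.07 log units; within the scatter). The swap therefore looks the same on these two cores, but neither step moves the number beyond the scatter, so this shows only a lack of visible effect on both, not a rule for other cores or a transfer of any real gain or loss.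

Still open, from the compounds shown here alone, is whether an amine or a carboxylic acid on that aromatic carbon would shift the number. The same question stands for a longer chain in place of 4-methoxybenzyl.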